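The compounds below may be only part of what the source reports. "The series", "measured", "known", "first", "only" and "open" are said of these compounds alone.

Working notes on a small series read in a functional assay on CCRF-CEM cells (Homo sapiens) for inhibition; on this read-out lower numbers stand for stronger inhibition and higher numbers for weaker inhibition. Compound 1 (`Nc1nc(O)c2ncn([C@@H]3O[C@@H](CO)C=C3F)c2n1`), which also bears hydroxy on an aromatic carbon, gives > 100000 nM, a limit and not a number. Compound 2 (`Nc1nc(=O)n([C@@H]2O[C@@H](CO)C=C2F)cc1F`) gives > 100000 nM, again a limit. Compound 3 (`Nc1ncnc2c1ncn2[C@@H]1O[C@@H](CO)C=C1F`) gives > 100000 nM, also a limit. Within the data shown here, the series so far shares (the limit of > 100000 nM in this assay, at which 3 of the 3 values shown sit), so no measured step is available to size a change. Compound 4 (`OC[C@H]1C=C(F)[C@H](n2cnc3c(O)ncnc32)O1`) has hydroxy in place of amino on an aromatic carbon. With compound 3 at > 100000 nM, a limit, no shift beyond the usual scatter is expected in either direction. Expected step: a number no higher from compound 3 to compound 4 (the limit leaves the size open). For compound 4 the estimated value is 100000 nM, with an expected range of 40000 nM to 250000 nM.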

Compound 4, half-maximal inhibitory concentration: > 100000 nM
Compound 4: only a limit was reported (the forecaster's own chance of this, stated with the estimate: 90%); the middle value sits exactly at the limit.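

No step can be read from compound 3 or compound 1 to compound 4, as both ends of each pair are limits: the limit of > 100000 nM in this assay, at which 4 of the 4 values shown sit. The compounds shown leave open whether any change on the shared core moves inhibition at all.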